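The source may report more compounds than this note shows. Statements on the series, on what has been measured and on what is new or still open speak of the compounds shown alone.

Working notes on the series. Of the compounds shown here, three have been measured: compound 1 `N[C@H]1CC[C@H](Nc2c(C(=O)NCc3ccc(F)cc3)nc(N3CCCCS3(=O)=O)c3cccnc23)CC1`, compound 2 `COc1ccc(CNC(=O)c2nc(Br)c3cccnc3c2N[C@H]2CC[C@H](N)CC2)cc1` and compound 3 `CS(=O)(=O)NCCCN(c1nc(C(=O)NCc2ccc(F)cc2)c(O)c2ncccc12)S(C)(=O)=O`; compound 4 `N[C@H]1CC[C@H](Nc2c(C(=O)NC3CCCCC3)nc(Br)c3cccnc23)CC1` has not. In a functional assay on HCT-116 cells (Homo sapiens) for cytotoxicity, read by MTT assay, with a stated time of 72 h (a lower number here means a stronger inhibitor, a higher number a weaker inhibitor), compound 1 returns a limit rather than a number, > 10000 nM, one of the values at the limit of > 10000 nM in this assay, at which 1 of the 3 values shown sits. Compound 3 gives 15000 nM in this assay. Compound 2 gives 3000 nM in this assay, the lowest of the two numbers, with compound 3 beyond the scatter above it. Compound 4 differs from compound 2 by cyclohexyl in place of 4-methoxybenzyl on an amide-type nitrogen. Within the data shown here, no measured step covers this change, so the expected step from compound 2 to compound 4 is a 1.5-fold higher number from compound 2 to compound 4 (0.18 log units; within the scatter), a modest loss that need not exceed the scatter. Compound 4 is therefore estimated at 4500 nM in this assay, within 1300 nM to 14000 nM.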

Compound 4, half-maximal inhibitory concentration: > 10000 nM
Compound 4 ended at the assay's limit (the forecaster's own chance of this, stated with the estimate: 20%); at least 2.2-fold (0.34 log units) between middle value and limit.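

Among these compounds, on the amide-type nitrogen, cyclohexyl in place of 4-methoxybenzyl is the first one-place change that can be read in this assay, and it gives an at least 3.3-fold higher number from compound 2 to compound 4 (0.52 log units; beyond the scatter) as the step. Compound 4 gives > 10000 nM as a limit and not a number, so the step has a lower bound but no measured size: the limit of > 10000 nM in this assay, at which 2 of the 4 values shown sit. On the core of compound 2, this exchange therefore costs more than the scatter.

Whether the aromatic ring, the methoxy oxygen or the carbon link to the ring accounts for the step stays open. A plain benzyl or a pyridylmethyl group on this nitrogen would help separate these.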